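Compound 3 Loses Its Methoxy Group

The source may hold more compounds than are shown below. What is called first, only, known or untested is meant among the compounds shown, and "the series" means these compounds.

Of the compounds shown here, three have so far been tested in a functional assay on HCT-116 cells (Homo sapiens) for antiproliferative activity, read by MTT assay, with a stated time of 72 h; on this read-out lower numbers stand for stronger inhibition and higher numbers for weaker inhibition. Going by the values given here, compound 1 `COc1ccc(N2C(=O)COc3ccc(-c4ccc(O)cc4)cc32)cc1` gives 26100 nM, the only exact number among them. Compound 2 `O=C1COc2ccc(-c3cnc(Cl)c(NS(=O)(=O)c4ccc(F)cc4)c3)cc2N1` reaches only a limit of the measurement, > 40000 nM. Compound 3 `COc1ccc(N2C(=O)COc3ccc(-c4cnc5ccccc5c4)cc32)cc1` likewise reaches only a limit, > 40000 nM. Compound 3 therefore has no exact number, and its place is the limit of > 40000 nM in this assay, at which 2 of the 3 values shown sit.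

The next compound, compound 4 `O=C1COc2ccc(-c3cnc4ccccc4c3)cc2N1c1ccccc1`, has hydrogen in place of methoxy on an aromatic carbon, para to a large group, so that 4-methoxyphenyl becomes phenyl: hydrogen in place of methoxy on an aromatic carbon. Among the compounds with values here, no pair of measured compounds differs by this change alone, so the data offer no direct guide to its size or direction. Within the data shown here, the one exact number, compound 1 at 26100 nM, lies high on the scale of this assay, and it gives no sign of strong inhibition in this small set. The expectation is therefore no change beyond the scatter, and another report of a limit is the likeliest result. The estimated step, a number no higher from compound 3 to compound 4 (the limit leaves the size open), is expected to stay within the usual scatter. Compound 4 is expected at about 40000 nM, with an estimated range from 20000 nM to 80000 nM.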

Compound 4, half-maximal inhibitory concentration: > 40000 nM
Compound 4 ended at the assay's limit; the forecaster's own chance of this, stated with the estimate: 65%; the middle value sits exactly at the limit.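

Compound 3 and compound 4 both give only a limit of the measurement, not an exact number, so no step can be read between them: the limit of > 40000 nM in this assay, at which 3 of the 4 values shown sit.

Still open, from the compounds shown here alone, is whether going from 4-methoxyphenyl to phenyl changes the result in this assay at all, and what exact number either compound would have.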